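Compound 4 and a limit without a number

The compounds below may be only part of what the source reports. "The series", "measured", "known", "first", "only" and "open" are said of these compounds alone.

Measured in a functional assay on HepG2 cells (Homo sapiens) for antiproliferative activity, read by XTT assay, with a stated time of 72 h; on this read-out lower numbers stand for stronger inhibition and higher numbers for weaker inhibition:
compound 1 `Cc1ncnc2c1c(-c1cc3ccccc3o1)cn2[C@@H]1O[C@H](CO)[C@@H](O)[C@H]1O` gives the limit > 20000 nM
compound 2 `Nc1nc(N)c2c(-c3cccs3)cn([C@@H]3O[C@H](CO)[C@@H](O)[C@H]3O)c2n1` gives the limit > 20000 nM
compound 3 `Cc1nc(N)c2c(-c3cccs3)cn([C@@H]3O[C@H](CO)[C@@H](O)[C@H]3O)c2n1` gives the limit > 20000 nM

Compound 3 gives only a limit (> 20000 nM) and no number. The two other measured compounds share that position (the limit of > 20000 nM in this assay, at which 3 of the 3 values shown sit), so compound 3 cannot be ranked against them.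

Compound 4 `C#Cc1cn([C@@H]2O[C@H](CO)[C@@H](O)[C@H]2O)c2nc(C)nc(N)c12` comes from compound 3 by one change, ethynyl in place of thiophen-2-yl on an aromatic carbon.

The only measured step between two of these compounds is a step that the two limits leave unreadable from compound 2 to compound 3, and it involves methyl in place of amino. That step has no readable size and leaves the thiophen-2-yl untouched. Among the measured compounds shown here, no measured step replaces the thiophen-2-yl, so the data give no direct size for this change.

With compound 3 at its limit (> 20000 nM), a result at that limit is expected for compound 4 too. A reading with a number remains possible, and it is expected to show somewhat stronger inhibition in this assay, given that only a limit is available as the starting point. The estimated change is an at least 1.2-fold lower number from compound 3 to compound 4 (0.09 log units; that floor lies within the scatter), and it is a loose expectation. The estimate for compound 4 is (16000 nM), with an expected range (1500 nM to 30000 nM).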

Compound 4, half-maximal inhibitory concentration: > 20000 nM
Compound 4 was reported as a limit; the forecaster's own chance of this, stated with the estimate: 65%; at least 1.2-fold (0.09 log units) between middle value and limit.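

In this assay compound 4 gives > 20000 nM, which is a limit and not a number. Compound 3 also stands at a limit, and the step from compound 3 to compound 4 cannot be read. The compounds shown leave open how strongly any of them inhibits and which change, if any, would yield a number: the limit of > 20000 nM in this assay, at which 4 of the 4 values shown sit.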